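The source may hold more compounds than are shown below. What is called first, only, known or untested is meant among the compounds shown, and "the series" means these compounds.

Measured in a functional assay on HT cells (Homo sapiens) for antiproliferative activity, read by fluorescence, with a stated time of 72 h; on this read-out lower numbers stand for stronger inhibition of growth and higher numbers for weaker inhibition of growth:
compound 1 `CC(C)c1n[nH]c2c(NCc3ccc(-c4ccccn4)cc3)nc(SCC(N)CN)nc12`: 480 nM
compound 2 `CSc1nc(NCc2ccc(-c3ccccn3)cc2)c2[nH]nc(C(C)C)c2n1`: 783 nM
compound 3 `CC(C)c1n[nH]c2c(NCc3ccc(-c4ccccn4)cc3)nc(SCC(N)=O)nc12`: 192 nM

Compound 3 has the lowest number of the three, and both gaps to it lie beyond the scatter: a 2.5-fold lower number from compound 1 to compound 3 (0.40 log units; beyond the scatter) and a 4.1-fold lower number from compound 2 to compound 3 (0.61 log units; beyond the scatter). The next compound is compound 4 `CC(C)c1n[nH]c2c(NCc3ccc(-c4ccccn4)cc3)nc(S)nc12`, which has not yet been measured. The change is hydrogen in place of carbamoylmethyl on a sulfur, or (carbamoylmethyl)sulfanyl to sulfanyl.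

Within the data shown here, no measured compound carries the sulfanyl group, so the estimate is an extrapolation. The closest guide is the loss of carbamoyl, read backwards from a 4.1-fold lower number from compound 2 to compound 3 (0.61 log units; beyond the scatter), since this step also concerns the group that leaves here. The other guide is a 1.6-fold higher number from compound 1 to compound 2 (0.21 log units; within the scatter), which shows two different chains on the sulfur with no separation beyond the scatter. Neither compound 1 nor compound 2 reaches the number of compound 3, so a modest move towards higher numbers in this assay is expected, of about the size seen for the carbamoyl group. The expected change is a 3.6-fold higher number from compound 3 to compound 4 (0.56 log units; beyond the scatter). For compound 4 the estimated value is 700 nM, with an expected range of 200 nM to 2500 nM.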

Compound 4, concentration for 50% growth inhibition: 2760 nM
For compound 4 the middle estimate is 3.9-fold (0.60 log units) below the measured one; the whole stated range lies below it.
By their numbers in this assay, from the lowest: compound 3; then compounds 1 and 2 (each within the scatter of the next); then compound 4.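

In this assay, among these compounds, the earlier compounds all carried a chain on the sulfur, so they compared chains only, whereas compound 4 shows what happens with no chain there. All three steps to the free sulfanyl go towards a higher number and lie beyond the scatter: hydrogen in place of carbamoylmethyl is the large one (a 14-fold higher number from compound 3 to compound 4 (1.16 log units; beyond the scatter)), hydrogen in place of methyl is modest (a 3.5-fold higher number from compound 2 to compound 4 (0.55 log units; beyond the scatter)), and hydrogen in place of 2,3-diaminopropyl is also modest (a 5.8-fold higher number from compound 1 to compound 4 (0.76 log units; beyond the scatter)), which leaves compound 4 the weakest of the four and shows that even methyl separates from the free sulfanyl. Nothing measured here bears on why the free sulfanyl stands apart.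

The compounds shown leave open whether the carbamoyl group itself accounts for the lead of compound 3 over compound 2, which a carboxylic acid or a methyl ester on the same chain would test. They also leave open whether a plain ethyl or longer alkyl chain on the sulfur, or an oxygen or an amine nitrogen in place of that sulfur, would hold the lower numbers.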